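Two hydroxyphenyl groups on a shared core: moving one hydroxyl

The source may report more compounds than this note shows. Statements on the series, on what has been measured and on what is new or still open speak of the compounds shown alone.

Measured so far:
compound 1, `Oc1cccc(-c2cc(-c3cccs3)cc(-c3ccccc3O)n2)c1`, > 50000 nM
compound 2, `Oc1ccc(-c2cc(-c3cccs3)cc(-c3ccccc3O)n2)cc1`, > 50000 nM
compound 3, `Oc1ccc(-c2cc(-c3cccs3)cc(-c3cccc(O)c3)n2)cc1`, 780 nM

All three compounds were tested in a functional assay on T47D cells (Homo sapiens) for cytotoxicity, read by CCK-8 assay; a higher number here means a weaker inhibitor, a lower number a stronger inhibitor. For compound 1 the value is a limit of the assay, not a number. For compound 2 the value is likewise a limit. Compound 3 is thus the only one of the three with a measured number, and two of the values sit at the limit described by the limit of > 50000 nM in this assay, at which 2 of the 3 values shown sit.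

Compound 4 is `Oc1ccc(-c2cc(-c3cccs3)cc(-c3ccc(O)cc3)n2)cc1`. It differs from compound 3 in one place: 4-hydroxyphenyl in place of 3-hydroxyphenyl on an aromatic carbon.

Three measured steps exist. The step of an at least 64-fold lower number from compound 1 to compound 3 (1.80 log units; beyond the scatter) and the step of an at least 64-fold lower number from compound 2 to compound 3 (1.80 log units; beyond the scatter) both replace a 2-hydroxyphenyl group and are large. For the measured compounds named here, the one step that matches the change from compound 3 to compound 4, a 3-hydroxyphenyl group giving way to a 4-hydroxyphenyl group, is a step that the two limits leave unreadable from compound 1 to compound 2, which cannot be read because both of its values are limits. So the measured steps give no direct size for the present change; the expectation is a modest step, in either direction, not far beyond the scatter.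

Compound 4 is therefore estimated at 1500 nM, with a range from 400 nM to 6000 nM, which corresponds to an expected step of a 1.9-fold higher number from compound 3 to compound 4 (0.28 log units; within the scatter).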

Compound 4, half-maximal inhibitory concentration: 11700 nM
For compound 4 the middle estimate is 7.8-fold (0.89 log units) below the measured one; the measured number lies above the stated range.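

With the other 4-hydroxyphenyl group kept in place, the position next to the ring nitrogen now gives a readable answer in this assay: moving only the hydroxyl around its ring, with the same atoms overall, gives a 15-fold higher number from compound 3 to compound 4 (1.18 log units; beyond the scatter). The 4-hydroxyphenyl group still does better here than the 2-hydroxyphenyl group, with an at least 4.2-fold lower number from compound 2 to compound 4 (0.63 log units; beyond the scatter). Among the three compounds that differ only at this position, compound 2, compound 3 and compound 4, the number is therefore lowest with the 3-hydroxyphenyl group, intermediate with the 4-hydroxyphenyl group and beyond the assay's limit with the 2-hydroxyphenyl group, so the hydroxyl's place on this ring matters at every step.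

From the compounds shown here alone, the same swap of 3-hydroxyphenyl for 4-hydroxyphenyl, on the core that carries a 2-hydroxyphenyl group, cannot be read, so whether it behaves alike there stays open, as both values are limits and not numbers: the limit of > 50000 nM in this assay, at which 2 of the 4 values shown sit. Also open is what a methoxyphenyl or an aminophenyl group would do at this position, and why the place of the hydroxyl counts for so much.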